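Replacing the carboxy group of compound 3

The source may report more compounds than this note shows. Statements on the series, on what has been measured and on what is new or still open speak of the compounds shown alone.

Of the compounds shown here, three sharing a core have been tested in a functional assay on MCF7 cells (Homo sapiens) for antiproliferative activity, read by MTT assay, with a stated time of 48 h; on this read-out lower numbers stand for stronger inhibition and higher numbers for weaker inhibition. Compound 1 (`CC(=O)OC/C1=C/C[C@](C)(CCC=C(C)C)/C=C/[C@@H](OC(=O)C=C(C)C)[C@](C)(OC(C)=O)/C=C/C1=O`) gives 3990 nM, compound 2 (`COC/C1=C/C[C@](C)(CCC=C(C)C)/C=C/[C@@H](OC(=O)C=C(C)C)[C@](C)(OC)/C=C/C1=O`) gives 16500 nM, and compound 3 (`CC(C)=CCC[C@]1(C)/C=C/[C@@H](OC(=O)C=C(C)C)[C@](C)(O)/C=C/C(=O)/C(C(=O)O)=C\C1`) gives 16100 nM. Compound 3 thus stands level with compound 2, within the scatter, while compound 1 carries a lower number, and that gap to compound 3 lies beyond the scatter.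

Compound 4 (`CC(C)=CCC[C@]1(C)/C=C/[C@@H](OC(=O)C=C(C)C)[C@](C)(O)/C=C/C(=O)/C(CN2CCN(C)CC2)=C\C1`) has not yet been measured. It departs from compound 3 in one place: (4-methylpiperazin-1-yl)methyl in place of carboxy on a double-bonded ring carbon. In words, (4-methylpiperazin-1-yl)methyl stands in place of carboxy on a double-bonded ring carbon.

Among the measured compounds shown here, no two measured compounds differ in a single place, so the data offer no direct precedent for this exchange. For the measured compounds named here, the only guide is the narrow span of the measured values, from compound 1 at 3990 nM to compound 3 at 16100 nM. On that basis, a modest move toward a lower number in this assay is expected, close to the size of the scatter. The expected change is a 2.0-fold lower number from compound 3 to compound 4 (0.30 log units; within the scatter). For compound 4 the estimated value is 8000 nM, with an expected range from 2500 nM to 25000 nM.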

Compound 4, half-maximal inhibitory concentration: 550 nM
For compound 4 the middle estimate is 15-fold (1.16 log units) above the measured one; measured number below the stated range.
By their numbers in this assay, from the lowest: compound 4; then compound 1; then compounds 3 and 2 (each within the scatter of the next).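

In this assay, among the compounds shown here, the exchange of carboxy for (4-methylpiperazin-1-yl)methyl on a double-bonded ring carbon gives a 29-fold lower number from compound 3 to compound 4 (1.47 log units; beyond the scatter), the first single-place step, and it shows that the group on this carbon can shift the read-out strongly. For the compounds shown here, the three earlier compounds could not show this, as none of them differed from another in one place only, and their values gave no sign of a step of this size. The change swaps a group with one hydrogen-bond donor for a larger one with none and adds a six-membered ring with two nitrogens, but no measurement here explains why the number falls.

Going by these compounds alone, the single step cannot separate the loss of carboxy from the arrival of the piperazine ring, so it remains open whether a simple dimethylaminomethyl group, a morpholin-4-ylmethyl group or a plain hydroxymethyl group on the same carbon would give a similar number. It also leaves open whether the methyl on the piperazine matters, a question that the unsubstituted piperazin-1-ylmethyl group would address.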